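The source may hold more compounds than are shown below. What is called first, only, known or untested is meant among the compounds shown, and "the series" means these compounds.

Compound 1 `c1ccc(-c2ccc(Cn3cncc3CNc3ccc(-c4onc5ccccc45)c(-c4ccccc4)c3)cc2)cc1` gives > 10000 nM in a toxicity assay on NIH3T3 cells (Mus musculus) for cytotoxicity, read by resazurin assay (on this read-out lower numbers stand for an effect already at smaller amounts and higher numbers for an effect only at larger amounts of compound), which is a limit of the assay rather than a number.
Compound 2 `N#Cc1ccc(NCc2cncn2Cc2ccc(-c3ccccc3)cc2)cc1-c1ccccc1` gives > 1000 nM, again only a limit.
Compound 3 `c1ccc(-c2ccc(Cn3cncc3CNc3ccc(-c4cncs4)c(-c4ccccc4)c3)cc2)cc1` gives > 1000 nM, also a limit.

Compound 3 thus stands at the limit of > 1000 nM in this assay, at which 2 of the 3 values shown sit, so no number is known for it, and none of the three compounds shows an effect within the amounts tested. The steps a step that the two limits leave unreadable from compound 1 to compound 3 and a step that the two limits leave unreadable from compound 2 to compound 3 each join two limits, so neither can be read in size or direction. The same holds for a step that the two limits leave unreadable from compound 1 to compound 2.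

Compound 4 `CNC(=O)c1ccc(NCc2cncn2Cc2ccc(-c3ccccc3)cc2)cc1-c1ccccc1` differs from compound 3 by methylcarbamoyl in place of 1,3-thiazol-5-yl on an aromatic carbon. Among the measured compounds shown here, the step that the two limits leave unreadable from compound 2 to compound 3 touches the same position but gives no readable size, so no measured step offers a basis for expecting a change beyond the scatter in this assay. Compound 4 is therefore expected to give 10000 nM, with a range from 3000 nM to 30000 nM, most likely once more reported only as a limit. The expected step that the limit leaves unreadable from compound 3 to compound 4 stands for no change worth noting.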

Compound 4, half-maximal effective concentration: > 1000 nM
Compound 4: no number, only a limit (the forecaster's own chance of this, stated with the estimate: 80%); the middle value is on the limit's open side.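

Compound 4 is again reported only as a limit, and compounds 1, 2 and 3 are limits too, which leaves none of its steps to those three readable in size or direction. The compounds shown leave open at what concentration any of them would produce an effect in this assay.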